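From Propyl to sec-Butyl Under a Cytotoxicity Limit

This account rests on a few compounds, and the source may have more. Where it says the series, first, only, none or still open, it means among the compounds named here.

Three compounds were tested in an ADME assay on MT4 cells (Homo sapiens) for activation, read by MTT assay (a lower number here means that less compound is tolerated, a higher number that more compound is tolerated), and none of them gave an exact number. Compound 1 (`CCC(C)Sc1nc(Cc2c(F)cccc2Cl)c(C)c(=O)[nH]1`) gives > 73000 nM as a limit of the assay. Compound 2 (`CCC(C)Sc1nc(C(C)c2c(F)cccc2Cl)cc(=O)[nH]1`) gives > 73000 nM as a limit as well. Compound 3 (`CCCSc1nc(C(C)c2c(F)cccc2Cl)c(C)c(=O)[nH]1`) gives > 1500 nM and this too is a limit. Its standing is therefore known only as a limit, and it is the only one of the three at that level.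

Compound 4 (`CCC(C)Sc1nc(C(C)c2c(F)cccc2Cl)c(C)c(=O)[nH]1`) has not yet been measured. It differs from compound 3 by methyl in place of hydrogen on a saturated chain carbon bound to a saturated chain carbon and a sulfur and in words this is methyl in place of hydrogen on a saturated chain carbon bound to a saturated chain carbon and a sulfur, which turns propylsulfanyl into (sec-butyl)sulfanyl.

Going by the values given here, no measured pair isolates this change, so any step in this assay rests on indirect evidence. Compound 2 also carries the (sec-butyl)sulfanyl group and shows > 73000 nM as a limit, so an upward move is expected. The expected change is a step that the limit leaves unreadable from compound 3 to compound 4 and is only an estimate, since it starts from a limit. Compound 4 is estimated at 40000 nM with an expected range from 3000 nM to 100000 nM in this assay, and it may well be reported only as a limit.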

Compound 4, half-maximal cytotoxic concentration: > 1500 nM
Compound 4: only a limit was reported (the forecaster's own chance of this, stated with the estimate: 75%); the middle value lies beyond the limit too.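

In this assay compound 4 gives > 1500 nM, a limit of the assay. Compounds 1, 2 and 3 also stand only as limits, so the steps from each of them to compound 4 cannot be read. The compounds shown leave open whether going from propyl to sec-butyl changes the tolerated concentration at all.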